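This account rests on a few compounds, and the source may have more. Where it says the series, first, only, none or still open, it means among the compounds named here.

In a functional assay on U-87MG ATCC cells for inhibition, with U-87 MG (Homo sapiens) as the target, read by MTT assay, with a stated time of 48 h (on this read-out higher numbers stand for weaker inhibition and lower numbers for stronger inhibition), compound 3 `COc1ccccc1-c1csc(N/N=C/c2cc(OC)c(OC)c(Br)c2Br)n1` gives only a limit, > 100000 nM, and no number. Compound 1 `COc1cc(/C=N/Nc2nc(-c3ccc(Br)cc3)cs2)cc(Br)c1OC` gives 27900 nM, and compound 2 `COc1cc(/C=N/Nc2nc(-c3ccc(F)c(F)c3)cs2)cc(Br)c1OC` gives 26300 nM. Among the measured compounds shown here, the single measured step, a 1.1-fold lower number from compound 1 to compound 2 (0.03 log units; within the scatter), lies within the scatter.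

Compound 4 `COc1ccccc1-c1csc(N/N=C/c2cc(Br)c(OC)c(OC)c2)n1` differs from compound 3 by one change: hydrogen in place of bromo on an aromatic carbon. With hydrogen in place of bromo, compound 4 carries the same brominated dimethoxy portion as compound 1 and compound 2, while keeping the methoxy-bearing aryl group of compound 3. For the measured compounds named here, no measured step covers this change directly, and the one available step lies elsewhere in the structure. It does suggest that the value may hold when the aryl group changes, so compound 4 is expected near compound 1 at 27900 nM. Compound 4 is thus expected to show stronger inhibition in this assay than the limit of compound 3. The expected step is an at least 3.3-fold lower number from compound 3 to compound 4 (0.52 log units; beyond the scatter). For compound 4 the estimated value is 30000 nM, with an expected range of 10000 nM to 90000 nM.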

Compound 4, half-maximal inhibitory concentration: > 100000 nM
Compound 4: a limit, no number; the forecaster's own chance of this, stated with the estimate: 15%; middle value at least 3.3-fold (0.52 log units) from the limit.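

In this assay the aryl group on the core proves to matter: 2-methoxyphenyl in place of 3,4-difluorophenyl (an at least 3.8-fold higher number from compound 2 to compound 4 (0.58 log units; beyond the scatter)) and 2-methoxyphenyl in place of 4-bromophenyl (an at least 3.5-fold higher number from compound 1 to compound 4 (0.55 log units; beyond the scatter)) both move the read-out beyond the scatter, whereas the exchange between the two halogenated aryl groups did not. With hydrogen in place of bromo, compound 4 still reads only as a limit, so this change does not bring the 2-methoxyphenyl compounds into a measurable range. The step between compound 3 and compound 4 cannot be read because both stand at a limit: the limit of > 100000 nM in this assay, at which 2 of the 4 values shown sit.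

Open, as far as these compounds go, is whether the methoxy group itself or its place on the phenyl ring drives the shift, which 4-methoxyphenyl or 2-fluorophenyl would help to separate. Also open, from the compounds shown here alone, is how an amine or a carboxylic acid on that aryl group would read.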